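Pyridinyl Replaces Trifluoromethoxyphenyl on the Ring Nitrogen

The compounds below may be only part of what the source reports. "The series", "measured", "known", "first", "only" and "open" are said of these compounds alone.

Three compounds have been measured in a functional assay on CHO cells with adenosine receptor A1 (Homo sapiens) as the target, read by cAMP accumulation and immunoassay, with a stated time of 6 min, tested at 0.1 uM; a higher number here means a weaker effect of the compound at the concentration tested, a lower number a stronger effect:
compound 1 `CC(C)N1CCN(Cc2csc(N)c2C(=O)c2ccc(Cl)cc2)CC1` gives 3.6%;
compound 2 `Nc1scc(CN2CCN(c3ccc(Cl)cc3F)CC2)c1C(=O)c1ccc(Cl)cc1` gives -9.4%;
compound 3 `Nc1scc(CN2CCN(c3ccc(OC(F)(F)F)cc3)CC2)c1C(=O)c1ccc(Cl)cc1` gives -13%.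

Compound 3 holds the lowest of the three numbers, yet the step of a number 3.6 percentage points lower from compound 2 to compound 3 (within the scatter) lies within the scatter, while a number 16.6 percentage points lower from compound 1 to compound 3 (beyond the scatter) lies beyond it. Compound 4 `Nc1scc(CN2CCN(c3cccnc3)CC2)c1C(=O)c1ccc(Cl)cc1` differs from compound 3 in one place: pyridin-3-yl in place of 4-(trifluoromethoxy)phenyl on an amine nitrogen in a ring. The two steps that bear on this are a number 13 percentage points lower from compound 1 to compound 2 (beyond the scatter) and a number 16.6 percentage points lower from compound 1 to compound 3 (beyond the scatter), both modest, and each replaced isopropyl with an aromatic ring; exchanging one aromatic ring for another, a number 3.6 percentage points lower from compound 2 to compound 3 (within the scatter), stayed within the scatter. Compound 4 keeps an aromatic ring in that place, so a step of a number 3 percentage points higher from compound 3 to compound 4 (within the scatter) within the scatter is expected. Compound 4 is therefore estimated at -10%, with a range from -25% to 5%.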

Compound 4, a percentage reported as activity, at one concentration (the size of the read-out at that concentration, not a potency): 3.4%
The estimate for compound 4 lay 13.4 percentage points below the measured number; the measured number falls inside the stated range.
By their numbers in this assay, from the lowest: compounds 3 and 2 (each within the scatter of the next); then compounds 4 and 1 (each within the scatter of the next).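

Exchanging one aromatic ring for another at this place can change the read-out after all: pyridin-3-yl gives a number 16.4 percentage points higher from compound 3 to compound 4 (beyond the scatter) and a number 12.8 percentage points higher from compound 2 to compound 4 (beyond the scatter) in this assay. Against isopropyl, the same ring gives a number 0.2 percentage points lower from compound 1 to compound 4 (within the scatter), so an aromatic ring alone does not bring the lower numbers seen with 4-(trifluoromethoxy)phenyl and 4-chloro-2-fluorophenyl. Nothing available here explains this difference.

Open, as far as these compounds go, is whether the change follows the ring nitrogen of pyridin-3-yl or the loss of the substituents on the phenyl rings. An unsubstituted phenyl ring at this place would separate the two.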